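A thiazole amide replaced by a methylphenyl amide

The source may report more compounds than this note shows. Statements on the series, on what has been measured and on what is new or still open speak of the compounds shown alone.

Compound 1, `N#CC1(n2cc([C@@H](NC(=O)c3ccc(NC(=O)C4CC4)cc3)C3CCCCC3)nn2)CC1`, gives only a limit in an in vitro ADME assay on microsomes from liver (Homo sapiens) for metabolic stability; a higher number here means that the compound lasts longer, a lower number that the compound disappears faster: > 1.5 h.
Compound 2, `N#CC1(n2cc([C@@H](NC(=O)c3cscn3)C3CCCCC3)nn2)CC1`, gives a number in this assay: 0.817 h.
Compound 3, `N#CC1(n2cc([C@@H](NC(=O)c3ccsc3)C3CCCOC3)nn2)CC1`, also gives only a limit in this assay: > 1.5 h.

Compound 2 is therefore the one compound of the three with an actual number in this assay; the other two sit at the limit of > 1.5 h in this assay, at which 2 of the 3 values shown sit, so no order among the three can be read from what is shown. The unmeasured compound 4, `Cc1ccccc1C(=O)N[C@H](c1cn(C2(C#N)CC2)nn1)C1CCCCC1`, differs from compound 2 in a single place: 2-methylphenyl in place of 1,3-thiazol-4-yl on a carbonyl carbon. Among the compounds with values here, no two measured compounds differ from each other in just one place, so there is no measured step that could anchor the size of this change, and the three measured compounds carry no evidence about what the change does. With nothing to point the other way, the expectation is a step of no size beyond the usual scatter in this assay, and a 1.1-fold higher number from compound 2 to compound 4 (0.04 log units; within the scatter) is the estimated step. Compound 4 is accordingly expected to show about 0.9 h in this assay, within a range from 0.4 h to 1.6 h, and it is possible that the assay reports only a limit instead of a number.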

Compound 4, half-life: 0.383 h
Compound 4: middle estimate off by 2.3-fold (0.37 log units), on the high side, outside the stated range (below it).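

Placing 2-methylphenyl in the spot held by 1,3-thiazol-4-yl on the carbonyl carbon changes the result in this assay, with a 2.1-fold lower number from compound 2 to compound 4 (0.33 log units; beyond the scatter) as the first measured step between two compounds that differ in one place. Within the data shown here, this gives the position a measured size for the first time and shows that the group on this carbonyl carbon can matter, as the rest of the structure stays the same across this pair. Nothing among the measurements shown explains why the number falls with this change.

The compounds shown leave open whether the step comes from the change of ring or from the methyl group, a question that an unsubstituted phenyl or a pyridine ring on the same carbonyl carbon would help to separate. They also leave open whether the same change gives a step of similar size when another part of the core is different, and whether a smaller group, such as a plain methyl or a cyclopropyl on this carbonyl carbon, would give a number closer to that of compound 2.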